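The source may report more compounds than this note shows. Statements on the series, on what has been measured and on what is new or still open speak of the compounds shown alone.

Measured so far:
compound 1 `Cc1cc(C)cc(-c2c(C)nn(-c3nc(-c4ccc(Cl)c(Cl)c4)c(SC(C)C)s3)c2C(=O)O)c1` gives 2700 nM
compound 2 `Cc1nn(-c2nc(-c3ccc(Cl)c(Cl)c3)c(SC(C)C)s2)c(C(=O)O)c1-c1cnn(C)c1` gives 6800 nM
compound 3 `Cc1nn(-c2nc(-c3ccc(Cl)c(Cl)c3)c(SC(C)C)s2)c(C(=O)O)c1-c1ccc(Cl)cc1` gives 2500 nM

All three values come from a functional assay on BJAB cells (Homo sapiens) for antiproliferative activity, with a stated time of 4 days; a higher number here means that more compound is needed for the effect, a lower number that less compound is needed. Compound 3 holds the lowest number of the three, though its gap to compound 1 is within the scatter, so the two cannot be ordered; only compound 2 stands apart, with a 2.7-fold lower number from compound 2 to compound 3 (0.43 log units; beyond the scatter).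

Compound 4 `COc1ccccc1-c1c(C)nn(-c2nc(-c3ccc(Cl)c(Cl)c3)c(SC(C)C)s2)c1C(=O)O` is not yet measured. It differs from compound 3 in one place: 2-methoxyphenyl in place of 4-chlorophenyl on an aromatic carbon.

The measured steps that bear on this are the other aryl swaps at the same carbon. Between the two phenyl variants the step was a 1.1-fold lower number from compound 1 to compound 3 (0.03 log units; within the scatter). Only the swap to the pyrazolyl ring moved the number beyond the scatter, with a 2.5-fold higher number from compound 1 to compound 2 (0.40 log units; beyond the scatter) and a 2.7-fold lower number from compound 2 to compound 3 (0.43 log units; beyond the scatter). Since compound 4 keeps a phenyl ring and changes only its substituent, the expected step of a 1.2-fold higher number from compound 3 to compound 4 (0.08 log units; within the scatter) is none beyond the scatter. Compound 4 is therefore estimated at 3000 nM, with a range from 1200 nM to 7500 nM.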

Compound 4, half-maximal effective concentration: 14700 nM
Estimate against measurement, compound 4: 4.9-fold (0.69 log units) below; the measured number lies above the stated range.
By their numbers in this assay, from the lowest: compounds 3 and 1 (each within the scatter of the next); then compound 2; then compound 4.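

In this assay, this aromatic carbon responds to the choice among phenyl groups and not only to the swap from phenyl to pyrazolyl: 2-methoxyphenyl gives a 5.9-fold higher number from compound 3 to compound 4 (0.77 log units; beyond the scatter) and a 5.4-fold higher number from compound 1 to compound 4 (0.74 log units; beyond the scatter), whereas the two earlier phenyl variants could not be ordered. Keeping a phenyl ring therefore does not by itself hold the number, and the 2-methoxyphenyl compound also lies past the pyrazolyl compound, with a 2.2-fold higher number from compound 2 to compound 4 (0.33 log units; beyond the scatter). Nothing measured here accounts for this rise.

Compound 4 is the only compound shown with a methoxy group, so the effect of the group itself cannot be separated from that of its place on the phenyl ring. On these data alone, how a hydroxy group or an amine in place of that methoxy group would read also remains open.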